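This account rests on a few compounds, and the source may have more. Where it says the series, first, only, none or still open, it means among the compounds named here.

Going by the values given here, in a physicochemical assay for lipophilicity (a higher number here means a more lipophilic compound, a lower number a more polar compound), compound 1 `CC(C)(C)n1ncc(OCc2nnc(-c3cccc(F)c3)o2)c(Cl)c1=O` gives 2.69 and compound 2 `CC(C)(C)n1ncc(OCc2nnc(-c3c(F)cccc3F)o2)c(Cl)c1=O` gives 2.75, and these are the only two numbers so far. The two lie within the scatter of each other, so compound 2 stands level with compound 1.

Compound 3 `CCc1ccc(-c2nnc(COc3cnn(C(C)(C)C)c(=O)c3Cl)o2)cc1` is not yet measured. It carries 4-ethylphenyl in place of 2,6-difluorophenyl on an aromatic carbon of the five-membered aromatic ring: 4-ethylphenyl in place of 2,6-difluorophenyl on an aromatic carbon. The heavy-atom count stays the same, while both fluorine atoms leave and the entering group holds carbon only.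

Among the compounds with values here, one measured step bears on this change: a number 0.06 log units higher from compound 1 to compound 2 (within the scatter). Within the data shown here, that step exchanges one fluorinated phenyl for another, and no measured compound carries an ethyl group, so it gives only a weak guide and the size of the next step rests mainly on the structural change. A clear upward move in this assay is expected, beyond the scatter. The expected step is a number 1.05 log units higher from compound 2 to compound 3 (beyond the scatter) in size. For compound 3 the estimate is 3.8, with an expected range from 3.3 to 4.3.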

Compound 3, partition coefficient: 3.52
The estimate for compound 3 lay 0.28 log units above the measured number; measured number inside the range.
By their numbers in this assay, from the lowest: compounds 1 and 2 (each within the scatter of the next); then compound 3.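

In this assay, the group on the aromatic carbon of the five-membered aromatic ring now gives a step beyond the scatter, a number 0.77 log units higher from compound 2 to compound 3 (beyond the scatter) and, with the other fluorinated phenyl as the starting point, a number 0.83 log units higher from compound 1 to compound 3 (beyond the scatter) in the same direction. Exchanging one fluorinated phenyl for the other had given only a number 0.06 log units higher from compound 1 to compound 2 (within the scatter) and so had left open whether this position could move the number at all; 4-ethylphenyl now places compound 3 clearly apart from compound 1 and compound 2, while the entering and leaving groups in the step from compound 2 hold the same count of heavy atoms. No measurement in hand gives a cause for this rise.

The step combines the loss of both fluorine atoms with the arrival of the ethyl group, so the share of each remains unresolved, and an unsubstituted phenyl or a 4-methylphenyl at this position would help separate them. On these data alone, how far the number moves with a longer alkyl chain, or in the opposite direction with a morpholine or a carboxylic acid on the phenyl ring, also remains open.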